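A few compounds are considered here, and "the series" means these few. Any claim that something is new, unique, unknown or untested is made for them only; others in the source may bear on it.

Measured so far in a functional assay on PC-3 cells (Homo sapiens) for antiproliferative activity, read by MTT assay; on this read-out higher numbers stand for weaker inhibition and lower numbers for stronger inhibition:

- compound 1 `Cc1cc(C)c(/C=N/Nc2ncc3c(n2)n(C2CCCC2)c(=O)c(=O)n3C)c(C)c1`: 13900 nM
- compound 2 `Cn1c(=O)c(=O)n(C2CCCC2)c2nc(N/N=C/c3ccccc3F)ncc21`: 27600 nM

Within the data shown here, only two numbers exist in this assay, and the step between them, a 2.0-fold higher number from compound 1 to compound 2 (0.30 log units; within the scatter), stays within the scatter of repeated measurements, so compound 2 and compound 1 cannot be told apart on this read-out.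

Compound 3 `Cn1c(=O)c(=O)n(C2CCCC2)c2nc(N/N=C/c3ccc(F)cc3F)ncc21` differs from compound 2 in one place: fluoro in place of hydrogen on an aromatic carbon. Among the measured compounds shown here, no measured step adds a fluoro to this ring; the one step on record, a 2.0-fold higher number from compound 1 to compound 2 (0.30 log units; within the scatter), exchanged the whole aryl group and produced no change beyond the scatter. Nothing in hand therefore points to a shift in either direction, and the step of a 1.0-fold lower number from compound 2 to compound 3 (0.01 log units; within the scatter) is expected to be small. Compound 3 is estimated at 27000 nM in this assay, with a range from 11000 nM to 65000 nM.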

Compound 3, half-maximal inhibitory concentration: 13200 nM
Compound 3: middle estimate off by 2.0-fold (0.31 log units), on the high side; low and high end bracket the measured number.
By their numbers in this assay, from the lowest: compounds 3, 1 and 2 (each within the scatter of the next, the first and the last beyond it).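

In this assay, among these compounds, a fluoro on the carbon para to a large group and meta to a fluoro group gives a 2.1-fold lower number from compound 2 to compound 3 (0.32 log units; beyond the scatter) as a modest change, the first single step in this small set to pass beyond the scatter. Replacing 2,4,6-trimethylphenyl with 2,4-difluorophenyl gives a 1.1-fold lower number from compound 1 to compound 3 (0.02 log units; within the scatter) and stays within the scatter, so these two aryl groups cannot be told apart on this read-out. No available evidence explains the effect of the added fluoro.

As far as these compounds go, it remains open whether the gain depends on the 2-fluoro group already on the ring or would also appear with a lone 4-fluorophenyl. From the compounds shown here alone, how chloro, methoxy or an amine would read on the same carbon also remains unknown.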